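Changing the Group on the Oxygen of Compound 3

The source may hold more compounds than are shown below. What is called first, only, known or untested is meant among the compounds shown, and "the series" means these compounds.

In a functional assay on RS4-11 cells (Homo sapiens) for inhibition, read by CCK-8 assay, with a stated time of 72 h (on this read-out higher numbers stand for weaker inhibition and lower numbers for stronger inhibition), compound 1 `CN(C)CCCNc1ccc(S(=O)(=O)NC(=O)c2ccc(N3CCN(CC4=C(c5ccc(C(F)(F)F)cc5)CC(C)(C)CC4)CC3)cc2Oc2cnc3[nH]ccc3c2)cc1[N+](=O)[O-]` gives 3.9 nM and compound 2 `CN1CCC(CNc2ccc(S(=O)(=O)NC(=O)c3ccc(N4CCN(CC5=C(c6ccc(C(F)(F)F)cc6)CC(C)(C)CC5)CC4)cc3Oc3cnc4[nH]ccc4c3)cc2[N+](=O)[O-])C1` gives 8.3 nM with a 2.1-fold higher number from compound 1 to compound 2 (0.33 log units; beyond the scatter) between them. Compound 3 `CC1(C)CCC(CN2CCN(c3ccc(C(=O)NS(=O)(=O)c4ccc(OCC5CCOC5)c([N+](=O)[O-])c4)c(Oc4cnc5[nH]ccc5c4)c3)CC2)=C(c2ccc(C(F)(F)F)cc2)C1` gives 47 nM and has the highest number of the three, which makes it the weakest inhibitor here. The measured steps that reach it are a 12-fold higher number from compound 1 to compound 3 (1.08 log units; beyond the scatter) and a 5.7-fold higher number from compound 2 to compound 3 (0.75 log units; beyond the scatter) and both put (oxolan-3-yl)methoxy in place of an amino side chain on an aromatic carbon. Compound 4 `CC(Oc1ccc(S(=O)(=O)NC(=O)c2ccc(N3CCN(CC4=C(c5ccc(C(F)(F)F)cc5)CC(C)(C)CC4)CC3)cc2Oc2cnc3[nH]ccc3c2)cc1[N+](=O)[O-])C1CCOCC1` keeps that oxygen but carries 1-(oxan-4-yl)ethyl in place of (oxolan-3-yl)methyl (1-(oxan-4-yl)ethyl in place of (oxolan-3-yl)methyl on an oxygen on an aromatic ring). For the measured compounds named here, no measured step exchanges one group on that oxygen for another, and the two steps to compound 3 replace the amino link itself, so they bear on this change only indirectly. Neither direction is favoured, and no shift beyond the scatter is expected. The expected step is a 1.2-fold lower number from compound 3 to compound 4 (0.07 log units; within the scatter) on this estimate. Compound 4 is estimated at 40 nM (range 13 nM to 120 nM).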

Compound 4, half-maximal inhibitory concentration: 269 nM
Beside the measured number, compound 4's estimate is 6.7-fold (0.83 log units) below it, outside the stated range (above it).
By their numbers in this assay, from the lowest: compound 1; then compound 2; then compound 3; then compound 4.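

In this assay, for the compounds shown here, the group on the oxygen proves to matter: 1-(oxan-4-yl)ethyl in place of (oxolan-3-yl)methyl gives a 5.7-fold higher number from compound 3 to compound 4 (0.76 log units; beyond the scatter) and so shows a shift at this position that the earlier steps, which changed the amino side chain or replaced the amino link itself, could not reveal. Compound 4 also lies well away from the amino compounds, with a 32-fold higher number from compound 2 to compound 4 (1.51 log units; beyond the scatter) and a 69-fold higher number from compound 1 to compound 4 (1.84 log units; beyond the scatter) on record, which makes it the weakest inhibitor of the four. No evidence is available that accounts for this shift.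

The compounds shown leave open whether the six-membered ring or the ethyl link carries the change, as the two groups differ in both at once. They also leave open how this assay would respond to an amine or a carboxylic acid on this oxygen.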